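A few compounds are considered here, and "the series" means these few. Any claim that something is new, unique, unknown or untested is made for them only; others in the source may bear on it.

Measured compounds:
Compound 3 `ClCc1ccc(Cn2cnc3c(Cl)nc(Cl)nc32)cc1`. In a functional assay on RPMI-8226 cells (Homo sapiens) for cytotoxicity, read by sulforhodamine B assay, with a stated time of 48 h (on this read-out lower numbers stand for stronger inhibition of growth and higher numbers for weaker inhibition of growth), compound 3 gives 3800 nM.
Compound 1 `Nc1nc(Cl)c2ncn(Cc3ccc(CCl)cc3)c2n1`. Compound 1 gives > 100000 nM, which is a limit of the assay and not a number.
Compound 2 `ClCc1cccc(Cn2cnc3c(Cl)nc(Cl)nc32)c1`. Compound 2 gives > 100000 nM, again a limit of the assay and not a number.

Compound 3 and compound 2 are built from the same atoms joined differently; the difference between the two cores is not broken down here. Compound 1 arises from compound 3 by one change, (amino in place of chloro on an aromatic carbon). That step is an at least 26-fold higher number from compound 3 to compound 1 (1.42 log units; beyond the scatter), a clear move toward weaker growth inhibition, and it carries compound 1 onto (the limit of > 100000 nM in this assay, at which 2 of the 3 values shown sit). Compound 4 `Nc1nc(Cl)c2ncn(Cc3cccc(CCl)c3)c2n1` has not yet been measured in this assay. It arises from compound 2 by the same change, (amino in place of chloro on an aromatic carbon). The starting point differs, though, because compound 2 already sits at the limit of > 100000 nM in this assay, at which 2 of the 3 values shown sit. A number for compound 4 is therefore expected to stay at or beyond that limit, with the expected step being a step that the limit leaves unreadable from compound 2 to compound 4. Compound 4 is estimated at 200000 nM, expected between 50000 nM and 1000000 nM, most likely reported again only as a limit.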

Compound 4, concentration for total growth inhibition: 11800 nM
For compound 4 the middle estimate is 17-fold (1.23 log units) above the measured one, and the stated range ends above it.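

In this assay, putting an amino group in place of the chloro group on the aromatic carbon gives an at least 8.4-fold lower number from compound 2 to compound 4 (0.92 log units; beyond the scatter), so this change does not carry over from one core to the other with the same direction or size: the same change on two cores in this assay, an at least 26-fold higher number (1.42 log units; beyond the scatter) from compound 3 to compound 1 and an at least 8.4-fold lower number (0.92 log units; beyond the scatter) from compound 2 to compound 4, at least 220-fold (2.34 log units) apart, beyond the scatter of two such steps

The value of compound 2, > 100000 nM, is a limit of the assay and not a number. These two pairs show that the result of this one swap can differ sharply with the core that carries it, but they do not show why it differs, and two pairs give no rule for predicting what the swap would do on a third core.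

The compounds shown leave open whether a methylamino or methoxy group in that same place would behave like the amino group on either core. Also open, on these data alone, is how each core would respond if a hydroxymethyl group replaced the chloromethyl group.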